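The source may hold more compounds than are shown below. What is called first, only, known or untested is meant among the compounds shown, and "the series" means these compounds.

Working notes on the series. In a functional assay on SW-620 cells (Homo sapiens) for cytotoxicity, read by MTT assay, with a stated time of 72 h (on this read-out higher numbers stand for weaker inhibition and lower numbers for stronger inhibition), compound 1 `COc1ccc(/C=C2\CCC/C(=C\c3ccc(Cl)cc3)C2=O)cc1OC` gives 5900 nM and compound 2 `COc1ccc(/C=C2\CCC/C(=C\c3ccccc3Br)C2=O)cc1OC` gives 5300 nM, so compound 2 stands level with compound 1 within the scatter. Among the measured compounds shown here, compound 3 `COc1ccc(/C=C2\CCC/C(=C\c3cccc(Br)c3)C2=O)cc1OC` has no measurement yet.

The structural change is 3-bromophenyl in place of 2-bromophenyl on a double-bonded chain carbon bound to a double-bonded ring carbon. It places 3-bromophenyl in place of 2-bromophenyl on a double-bonded chain carbon bound to a double-bonded ring carbon, and the two compounds have the same atoms, joined differently.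

For the measured compounds named here, only one measured step bears on this change: a 1.1-fold lower number from compound 1 to compound 2 (0.05 log units; within the scatter). Going by the values given here, that step occurs at the same place but exchanges 4-chlorophenyl for 2-bromophenyl, so it is indirect evidence, and no measured pair isolates the change from 2-bromophenyl to 3-bromophenyl. With that single step within the scatter as the guide, no shift beyond the scatter is expected in this assay, and no direction can be assigned. The expected size is no change at the digits printed from compound 2 to compound 3 (within the scatter). For compound 3 the estimated value is 5300 nM, with an expected range of 2400 nM to 11500 nM.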

Compound 3, half-maximal inhibitory concentration: 4200 nM
Estimate against measurement, compound 3: 1.3-fold (0.10 log units) above; measured number inside the range.
By their numbers in this assay, from the lowest: compounds 3, 2 and 1 (each within the scatter of the next).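

In this assay, among the compounds shown here, 3-bromophenyl in place of 2-bromophenyl on a double-bonded chain carbon bound to a double-bonded ring carbon gives a 1.3-fold lower number from compound 2 to compound 3 (0.10 log units; within the scatter) and is the first step here with the same atoms joined differently, so a change in where the bromine sits on the phenyl ring, between these two arrangements, does not register beyond the scatter at this position. Set against the 4-chlorophenyl of compound 1, the 3-bromophenyl gives a 1.4-fold lower number from compound 1 to compound 3 (0.15 log units; within the scatter) and thus leaves all three halogen-bearing phenyl groups level, with no order among them. No measurement of any other property accompanies these values, and the level result carries no explanation.

On these data alone, all three compounds carry a halogen on the phenyl ring at this place, so it remains open whether an unsubstituted phenyl, a 4-aminophenyl or a 4-carboxyphenyl would stay level with them or move beyond the scatter. The rest of the shared core is the same throughout, which leaves open how far this flat picture depends on it.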